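The compounds below may be only part of what the source reports. "The series", "measured", "known", "first", "only" and "open" are said of these compounds alone.

In a physicochemical assay for acid dissociation, compound 2 `COc1cccc(CNCCCNc2ccnc3cc(Cc4cccc(C(F)(F)F)c4)ccc23)c1O` gives 9.47 and stands level with compound 1 `CCC(CC)c1ccc2c(NCCCNCc3cccc(OC)c3O)ccnc2c1`, which gives 9.47; the step of no change at the digits printed from compound 1 to compound 2 (within the scatter) lies within the scatter. Compound 3 `COc1cccc(CNCCCNc2ccnc3cc(CCc4ccccc4)ccc23)c1O` differs from compound 2 by benzyl in place of 3-(trifluoromethyl)phenyl on a saturated chain carbon bound to an aromatic carbon. Going by the values given here, the one measured step that touches this part of the core is no change at the digits printed from compound 1 to compound 2 (within the scatter), and it showed no change in the acid dissociation constant, so the author expects a step of about no change at the digits printed from compound 2 to compound 3 (within the scatter), none beyond the scatter. For compound 3 the estimate is 9.47, with a range from 9.2 to 9.75.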

Compound 3, acid dissociation constant: 9.47
For compound 3 middle estimate and measured number coincide at the digits printed; the measured number falls inside the stated range.
By their numbers in this assay, from the lowest: compounds 1, 2 and 3 (each within the scatter of the next).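

In this assay, removing the trifluoromethyl group and lengthening the link, with benzyl in place of 3-(trifluoromethyl)phenyl on a saturated chain carbon bound to an aromatic carbon, gives no change at the digits printed from compound 2 to compound 3 (within the scatter) and so leaves the reading where it stood. Phenethyl in place of pentan-3-yl on an aromatic carbon gives no change at the digits printed from compound 1 to compound 3 (within the scatter) as well, so three different groups at this place now read alike. Nothing further measured bears on why this is so. On these data alone, whether an amine or a carboxylic acid on this chain would move the number remains open.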